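The compounds below may be only part of what the source reports. "The series", "measured", "known", "first", "only" and "open" are said of these compounds alone.

Of the compounds shown here, three with related cores have numbers so far. In a physicochemical assay for solubility, measured as kinetic solubility (a lower number here means a less soluble compound, a higher number a more soluble compound), compound 1 `Cc1cnc(NC(=O)c2cc(Oc3cnc(C(=O)N(C)C)cn3)c3cc(C)oc3c2)cn1` gives 176000 nM and compound 2 `Cc1cnc(NC(=O)c2cc(Oc3cnc(C(=O)N(C)C)cn3)c3cc(C)nn3c2)cn1` gives 123000 nM. Compound 3 `Cc1cnc(NC(=O)c2cc(Oc3ccc(C(=O)N(C)C)cc3)c3cn(C)nc3c2)cn1` gives 351000 nM. Within the data shown here, that number lies within the scatter of the one for compound 1, and it stands higher than the one for compound 2 by a margin beyond the scatter.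

The next compound departs from compound 3 in a single place. Compound 4 `CCS(=O)(=O)c1ccc(Oc2cc(C(=O)Nc3cnc(C)cn3)cc3nn(C)cc23)cc1` carries ethylsulfonyl in place of dimethylcarbamoyl on an aromatic carbon, para to a large group (ethylsulfonyl in place of dimethylcarbamoyl on an aromatic carbon). Among the measured compounds shown here, no measured pair of compounds isolates this exchange, or any other single change, so the data offer no direct precedent for it. The three measured compounds differ from one another in more than one place, yet their numbers stay fairly close together, and that closeness is the main guide here. A modest downward step in this assay is expected, one that may not clear the scatter by much. Compound 4 is estimated at 200000 nM, with an expected range from 70000 nM to 450000 nM. This estimate means an expected change a 1.8-fold lower number from compound 3 to compound 4 (0.24 log units; within the scatter). The measurement itself will settle the matter.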

Compound 4, solubility: 69000 nM
Compound 4: middle estimate off by 2.9-fold (0.46 log units), on the high side; measured number outside the range, below it.
By their numbers in this assay, from the lowest: compounds 4, 2, 1 and 3 (each within the scatter of the next, the first and the last beyond it).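

In this assay, among these compounds, the exchange of dimethylcarbamoyl for ethylsulfonyl on an aromatic carbon, para to a large group, gives a 5.1-fold lower number from compound 3 to compound 4 (0.71 log units; beyond the scatter) and is the first single-place step, one that lies beyond the scatter. The earlier compounds shown here differed in more than one place and could not show that this position matters, yet here two groups of 5 heavy atoms, each without a ring, a hydrogen-bond donor or a net charge, are clearly told apart in this read-out. The data offer nothing that explains the size of this step.

On these data alone, it remains open whether the sulfonyl unit or the ethyl chain accounts for the step, and whether methylsulfonyl, an unsubstituted sulfonamide or a morpholine amide at this place would fall nearer compound 3 or compound 4. As far as these compounds go, it is also open whether the same exchange would give a step of similar size on the different cores of compound 1 and compound 2, whose ring at this position also differs from that of compound 3.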